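Quinoxaline-type diamines: aryl ether, thioether and benzylamine

The source may hold more compounds than are shown below. What is called first, only, known or untested is meant among the compounds shown, and "the series" means these compounds.

Measured so far in a functional assay on UO-31 cells (Homo sapiens) for inhibition, read by sulforhodamine B assay, with a stated time of 48 h; a higher number here means a weaker inhibitor of growth, a lower number a stronger inhibitor of growth:
- compound 1 `Nc1cc(N)c2nc(-c3ccccc3)c(Oc3ccc(Cl)c(Cl)c3)nc2c1`, reported only as a limit, < 100000 nM
- compound 2 `Nc1cc(N)c2nc(-c3ccccc3)c(NCc3ccc(F)cc3)nc2c1`, reported only as a limit, < 100000 nM
- compound 3 `Nc1cc(N)c2nc(-c3ccccc3)c(Sc3ccc(Cl)c(Cl)c3)nc2c1`, reported only as a limit, < 100000 nM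

Compound 3 therefore stands at the assay limit, and the two other values shown sit at the same limit (the limit of < 100000 nM in this assay, at which 3 of the 3 values shown sit). None of the three pairs gives a readable step: a step that the two limits leave unreadable from compound 1 to compound 3, a step that the two limits leave unreadable from compound 1 to compound 2 and a step that the two limits leave unreadable from compound 2 to compound 3 are all unreadable because both ends are limits.

Compound 4 `Nc1cc(N)c2nc(-c3ccccc3)c(Oc3ccc(F)cc3)nc2c1` differs from compound 3 by 4-fluorophenoxy in place of (3,4-dichlorophenyl)sulfanyl on an aromatic carbon. The closest measured comparison is the exchange of the sulfanyl link for the oxy link with the same dichlorophenyl ring, from compound 1 to compound 3, and the exchange of the dichlorophenyl for a fluorinated group, from compound 1 to compound 2; neither gives a size. The expected step is a step that the limit leaves unreadable from compound 3 to compound 4, meaning no reading beyond the scatter can be foreseen. Compound 4 is estimated at 40000 nM, with a range from 8000 nM to 100000 nM, and most probably the assay will again report only a limit.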

Compound 4, concentration for total growth inhibition: 45700 nM
Estimate against measurement, compound 4: 1.1-fold (0.06 log units) below, within the range that was stated.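

The steps from compound 1, compound 2 and compound 3 to compound 4 cannot be read, because each of those three compounds is reported only as a limit: the limit of < 100000 nM in this assay, at which 3 of the 4 values shown sit.

The compounds shown leave open how far compound 1, compound 2 and compound 3 actually lie from compound 4, and whether the linking atom or the aryl substituents affect growth inhibition.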